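Swapping a sulfonate oxygen for a methylene on the aryl tail

This account rests on a few compounds, and the source may have more. Where it says the series, first, only, none or still open, it means among the compounds named here.

Measured compounds:
- Compound 1, `C[C@@H]1CN(c2nnc(C(F)(F)F)o2)CCN1c1ncc(OCc2ccc(OS(C)(=O)=O)cc2F)cn1`: 82%
- Compound 2, `C[C@@H]1CN(c2nnc(C(F)(F)F)o2)CCN1c1ncc(OCc2ccc(CS(C)(=O)=O)cc2)cn1`: 95%
- Compound 3, `C[C@@H]1CN(C(=O)OC2(C(F)(F)F)COC2)CCN1c1ncc(OCc2ccc(OS(C)(=O)=O)cc2F)cn1`: 98%

All three were tested in a functional assay on HEK293S cells with Glucose-dependent insulinotropic receptor (Mus musculus) as the target, read by HTRF and cAMP accumulation, with a stated time of 45 min; a lower number here means a smaller maximal response, a higher number a larger maximal response. Compound 3 carries the largest of the three numbers, but the gap to compound 2 is within the usual scatter, so these two cannot be told apart; only compound 1 is clearly below it, as the step of a number 16 percentage points higher from compound 1 to compound 3 (beyond the scatter) shows.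

Compound 4, `C[C@@H]1CN(C(=O)OC2(C(F)(F)F)COC2)CCN1c1ncc(OCc2ccc(CS(C)(=O)=O)cc2F)cn1`, is not yet measured. It keeps the carbamate end of compound 3 and changes only the aryl tail: (methylsulfonyl)methyl in place of (methylsulfonyl)oxy on an aromatic carbon.

For the measured compounds named here, one measured step bears on this: a number 13 percentage points higher from compound 1 to compound 2 (beyond the scatter). That step, however, also removed the fluoro group, so it is not a clean comparison. Both compounds 2 and 3 already lie close to the reference agonist, leaving little room for a further rise. The expected step is therefore a number 2 percentage points higher from compound 3 to compound 4 (within the scatter), that is, no change beyond the scatter, with a slight upward lean because of a number 13 percentage points higher from compound 1 to compound 2 (beyond the scatter).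

Compound 4 is expected to give about 100%, with a likely range from 88% to 112%.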

Compound 4, intrinsic activity: the largest response reached, in percent of the reference agonist's in the Glucose-dependent insulinotropic receptor assay: 108%
Compound 4: middle estimate off by 8 percentage points, on the low side, within the range that was stated.
By their numbers in the Glucose-dependent insulinotropic receptor assay, from the lowest: compound 1; then compounds 2, 3 and 4 (each within the scatter of the next, the first and the last beyond it).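

For the compounds shown here, compound 4 gives the first clean reading of this exchange, since the fluoro group stays in place and only the (methylsulfonyl)oxy group gives way to (methylsulfonyl)methyl on the aromatic carbon. In the Glucose-dependent insulinotropic receptor assay, the result is a number 10 percentage points higher from compound 3 to compound 4 (within the scatter), so compound 3 and compound 4 cannot be told apart by their maximal response, and this position accepts the exchange without a measurable loss. The earlier compounds gave no view of lipophilicity, but in a physicochemical assay for lipophilicity, in phosphate buffer, at pH 7.4 (a lower number here means a more polar compound, a higher number a more lipophilic compound), compound 3 gives 3.7 and compound 4 gives 2.9, which shows that the exchange makes the molecule more polar while the maximal response holds: the measured distribution coefficient of compound 3, 3.7, and of compound 4, 2.9, a number 0.80 log units lower (beyond the scatter)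

The compounds shown leave open whether this position would also accept a carboxylic acid or a primary amide in place of (methylsulfonyl)methyl, and whether a longer chain between the sulfonyl group and the aromatic ring would do the same. They also leave open what the fluoro group contributes when the ((3-(trifluoromethyl)oxetan-3-yl)oxy)carbonyl end is present, since compound 3 and compound 4 both carry it.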